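Lengthening the crotonamide-type chain: compound 3 to compound 4

The compounds below may be only part of what the source reports. "The series", "measured", "known", "first", "only" and "open" are said of these compounds alone.

- compound 1 `CCC/C=C/C(=O)Nc1cccc(Oc2nc(Nc3ccn(C)n3)nc3c2CSCC3)c1` gives 17000 nM
- compound 2 `C=CC(=O)Nc1cccc(Oc2nc(Nc3ccc(OC)cc3)nc3c2CSCC3)c1` gives 20900 nM
- compound 3 `C/C=C/C(=O)Nc1cccc(Oc2nc(Nc3ccc(OC)cc3)nc3c2CSCC3)c1` gives > 50000 nM as a limit

In a functional assay on HeLa cells (Homo sapiens) for antiproliferative activity, read by MTT assay, with a stated time of 72 h (a higher number here means a weaker inhibitor, a lower number a stronger inhibitor), compound 3 has no number and stands at the limit of > 50000 nM in this assay, at which 1 of the 3 values shown sits, as a limit. Compound 4 `CCC/C=C/C(=O)Nc1cccc(Oc2nc(Nc3ccc(OC)cc3)nc3c2CSCC3)c1` differs from compound 3 by ethyl in place of hydrogen on a saturated chain carbon bound to a double-bonded chain carbon and so turns prop-1-en-1-yl into pent-1-en-1-yl. Among the compounds with values here, no measured step covers this change. The nearest, on the same carbonyl, is an at least 2.3-fold higher number from compound 2 to compound 3 (0.37 log units; beyond the scatter) and it runs toward weaker inhibition. Compound 1 carries the same (pent-1-en-1-yl)carbonyl and gives 17000 nM as a real number. Weak inhibition near the limit is therefore expected, with no large step, estimated as an at least 1.2-fold lower number from compound 3 to compound 4 (0.09 log units; that floor lies within the scatter) at most loosely. For compound 4 the estimated value is 40000 nM with an expected range of 15000 nM to 90000 nM in this series.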

Compound 4, half-maximal inhibitory concentration: 12800 nM
Compound 4: the middle estimate sits 3.1-fold (0.49 log units) above what was measured, and the stated range ends above it.
By their numbers in this assay, from the lowest: compounds 4, 1 and 2 (each within the scatter of the next). At a limit, above all of these: compound 3.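

In this assay, going from prop-1-en-1-yl to pent-1-en-1-yl on the carbonyl gives an at least 3.9-fold lower number from compound 3 to compound 4 (0.59 log units; beyond the scatter), so ethyl in place of hydrogen at this place brings back a real number. Compound 3 has only a limit: the limit of > 50000 nM in this assay, at which 1 of the 4 values shown sits. Pent-1-en-1-yl and vinyl on the carbonyl are not separated, at a 1.6-fold lower number from compound 2 to compound 4 (0.21 log units; within the scatter), and neither are the two nitrogen substituents, at a 1.3-fold lower number from compound 1 to compound 4 (0.12 log units; within the scatter).

Going by these compounds, whether a longer chain such as hept-1-en-1-yl, or a chain bearing an amine, keeps this level remains open. Also open, on these data alone, is whether prop-1-en-1-yl gives the same loss with 1-methyl-1H-pyrazol-3-yl on the nitrogen.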